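Removing all fluorines from the anilino ring: an estimate

This account rests on a few compounds, and the source may have more. Where it says the series, first, only, none or still open, it means among the compounds named here.

Three compounds share one core and were tested in a functional assay on A549 cells (Homo sapiens) for antiproliferative activity, read by MTT assay, with a stated time of 72 h; on this read-out lower numbers stand for stronger inhibition and higher numbers for weaker inhibition:

compound 1, `COc1cc2ncnc(Nc3ccc(Cl)c(C(F)(F)F)c3)c2cc1OCCCCC(=O)Nc1ccc(S(N)(=O)=O)cc1`: 9270 nM
compound 2, `COc1cc2ncnc(Nc3cccc(F)c3)c2cc1OCCCCC(=O)Nc1ccc(S(N)(=O)=O)cc1`: a limit, > 40000 nM
compound 3, `COc1cc2ncnc(Nc3cc(F)c(F)c(F)c3)c2cc1OCCCCC(=O)Nc1ccc(S(N)(=O)=O)cc1`: a limit, > 40000 nM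

Compound 3 therefore stands only at a limit of this assay, not at a number; the limit of > 40000 nM in this assay, at which 2 of the 3 values shown sit, applies to it. The change from compound 1 to the fluorinated anilines was an at least 4.3-fold higher number from compound 1 to compound 2 (0.63 log units; beyond the scatter) and an at least 4.3-fold higher number from compound 1 to compound 3 (0.63 log units; beyond the scatter), so both fluorinated analogues are clearly weaker than compound 1. Between compound 2 and compound 3 the step is a step that the two limits leave unreadable from compound 2 to compound 3.

Compound 4, `COc1cc2ncnc(Nc3ccccc3)c2cc1OCCCCC(=O)Nc1ccc(S(N)(=O)=O)cc1`, carries the change (phenyl in place of 3,4,5-trifluorophenyl on a nitrogen on an aromatic ring). Among the compounds with values here, no measured step here concerns a plain phenyl, and the two closest neighbours, compound 2 and compound 3, both sit at the limit. It is therefore expected that compound 4 stays in the same weak region, with a step of a number no higher from compound 3 to compound 4 (the limit leaves the size open) that cannot be read as a real change. The estimate for compound 4 in this assay is 40000 nM, with a range from 15000 nM to 110000 nM, and most likely the assay again reports only a limit.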

Compound 4, half-maximal inhibitory concentration: > 40000 nM
Compound 4 ended at the assay's limit (the forecaster's own chance of this, stated with the estimate: 65%); the middle value sits exactly at the limit.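

In this assay, removing all the fluorines from the anilino ring does not bring a measurable value, and the plain phenyl of compound 4 joins the fluorinated analogues at the limit: the limit of > 40000 nM in this assay, at which 3 of the 4 values shown sit. The steps among compound 2, compound 3 and compound 4 cannot be read, so these compounds do not show whether fluorine on this ring strengthens or weakens the effect, or makes no difference. Within the data shown here, the one readable new step is an at least 4.3-fold higher number from compound 1 to compound 4 (0.63 log units; beyond the scatter), which lies beyond the usual scatter and shows that the unsubstituted ring, like the two fluorinated ones, gives a clearly weaker result than the 4-chloro-3-(trifluoromethyl)phenyl group, the only group here with a measured number.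

The compounds shown leave open whether a chlorine alone or a trifluoromethyl group alone on the anilino ring would be enough to give a measurable value. They also leave open what a bromine or a methoxy group on that ring would do in this assay.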